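The compounds below may be only part of what the source reports. "The series", "measured", "known", "first", "only" and "open" are said of these compounds alone.

The study concerns two compounds that have been measured in a functional assay on ileum for inhibition of histamine H1 receptor (Cavia porcellus); on this read-out higher numbers stand for weaker inhibition and lower numbers for stronger inhibition. Compound 1 `CCSCCn1c(N2CCN(C)CC2)nc2ccccc21` gives 19 nM in this assay. Compound 2 `CCCOCCn1c(N2CCCN(C)CC2)nc2ccccc21` gives 16 nM in this assay. Within the data shown here, these two numbers lie within the scatter of each other, so neither compound can be set apart from the other on this read-out, and since the two structures differ in more than one place no single step between them can be counted.

Compound 3 `CN1CCN(c2nc3ccccc3[nH]2)CC1` has not yet been measured in this assay. It differs from compound 1 by hydrogen in place of 2-(ethylsulfanyl)ethyl on an aromatic nitrogen. Among the measured compounds shown here, no step between measured compounds shows what such a change does to the inhibition here, and both measured compounds carry a chain on that aromatic nitrogen, so compound 3 is the first without one. The expectation for compound 3 is therefore a move towards weaker inhibition, well beyond the scatter, with an estimated step of a 16-fold higher number from compound 1 to compound 3 (1.20 log units; beyond the scatter). In this assay compound 3 is expected to give about 300 nM, within an estimated range from 60 nM to 2000 nM.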

Compound 3, half-maximal inhibitory concentration: > 3000 nM
Compound 3: no number, only a limit (the forecaster's own chance of this, stated with the estimate: 15%); middle value at least 10-fold (1.00 log units) away from the limit.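

In this assay compound 3 gives > 3000 nM, which is a limit of the assay and not a number. Replacing 2-(ethylsulfanyl)ethyl with hydrogen on the aromatic nitrogen gives an at least 150-fold higher number from compound 1 to compound 3 (2.19 log units; beyond the scatter), so what sits on this nitrogen has a large bearing on the inhibition of compound 1. As far as these compounds go, compound 1 and compound 2 could not show this, as both carry a chain on that nitrogen, and the upper size of the step stays unknown, as it rests on a single reading: the limit of > 3000 nM in this assay, at which 1 of the 3 values shown sits.

The compounds shown leave open how much of the chain is needed, since a single methyl or ethyl group on that nitrogen would show whether a short alkyl group is enough to recover the inhibition or whether the full chain is required. They also leave open whether the sulfur itself matters, a question that an ether oxygen in its place on the same chain, with the 4-methylpiperazin-1-yl group kept, could settle, because compound 2 differs from compound 1 in more than one place.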